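The source may hold more compounds than are shown below. What is called first, only, known or untested is meant among the compounds shown, and "the series" means these compounds.

In a functional assay on the whole organism (spleen, spleen) with Rattus norvegicus as the target (a lower number here means that less compound is needed, a higher number that more compound is needed for the effect), compound 1, `CCCCCCCOc1ccc(CC[C@@](N)(CO)CCC)cc1`, gives 4.4 mg/kg. Compound 2, `CCCCCCCOc1ccc(CCC(N)(CO)CCCC)cc1`, does not give a number in this assay; it sits at the limit > 10 mg/kg, and the limit of > 10 mg/kg in this assay, at which 1 of the 2 values shown sits, is that limit. Within the data shown here, the step of an at least 2.2-fold higher number from compound 1 to compound 2 (0.35 log units; beyond the scatter) is the only measured step in the set, and it falls on the same saturated chain carbon that compound 3 now changes, though with a different exchange of groups. Compound 3, `CCCCCCCOc1ccc(CC[C@@](N)(CO)CCO)cc1`, differs from compound 2 as follows: a group of 7 heavy atoms (4 carbon, 1 nitrogen, 2 oxygen; no ring) in place of a group of 8 heavy atoms (6 carbon, 1 nitrogen, 1 oxygen; no ring), on a saturated chain carbon, two bonds along the chain from an aromatic carbon. Compound 3 carries a defined stereocentre, as compound 1 does, whereas compound 2 carries none. Among the measured compounds shown here, no measured step covers an exchange of this kind, so the measured step gives no direction for it. The expectation rests on compound 2 standing at a limit. It also rests on compound 1 giving 4.4 mg/kg with the same defined stereocentre. Compound 3 is therefore expected to come back into the measurable range, at an estimated 5 mg/kg, between 1.5 mg/kg and 15 mg/kg. The expected step of an at least 2.0-fold lower number from compound 2 to compound 3 (0.30 log units; that floor lies within the scatter) is read against a limit, not a number, and is correspondingly uncertain.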

Compound 3, dose for 50% inhibition: 0.018 mg/kg
Compound 3: the middle estimate sits 280-fold (2.44 log units) above what was measured; the measured number lies below the stated range.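

In this assay, hydroxy in place of methyl on a saturated chain carbon, three bonds along the chain from an amine nitrogen, gives a 240-fold lower number from compound 1 to compound 3 (2.39 log units; beyond the scatter), which shows that a single exchange at this place can move the number far more than the earlier step, an exchange of carbon chains, had revealed. Compound 2 stands at a limit, not a number: the limit of > 10 mg/kg in this assay, at which 1 of the 3 values shown sits. Against that limit the step reads an at least 550-fold lower number from compound 2 to compound 3 (2.74 log units; beyond the scatter), a floor rather than a measured size, and this exchange also brings in the defined stereocentre that compound 2 lacks, so the step from compound 1, where that stereocentre is already present, is the cleaner reading of the hydroxy.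

The compounds shown leave open whether the gain belongs to hydroxy alone or would also come with an amine, a methoxy or a carboxylic acid at that same carbon, and whether a longer chain carrying the hydroxy would keep it. They also leave open what the opposite configuration at the defined stereocentre would give.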